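Swapping a Phenoxy Group for Piperidine on a Shared Core

The compounds below may be only part of what the source reports. "The series", "measured", "known", "first", "only" and "open" are said of these compounds alone.

Measured compounds:
compound 1, `N#Cc1c(-c2ccc(Oc3ccccc3)cc2)ccn2c(CC(F)(F)F)cnc12`, 200%
compound 2, `CCCc1cnc2c(C#N)c(N3CCN(c4ccccc4)CC3)ccn12`, 241%
compound 3, `CCc1cnc2c(C#N)c(N3CCN(c4ncccn4)CC3)ccn12`, 214%

These three compounds share a core and were tested in a functional assay on CHO cells with metabotropic glutamate receptor 2 (Homo sapiens) as the target, read by GTPgammaS binding; a higher number here means a larger maximal response, a lower number a smaller maximal response. Compound 1 gives 200%, the lowest of the three numbers. Its nearest neighbour is compound 3 with 214%, a gap that lies beyond the usual scatter, and compound 2 with 241% stands furthest away, also beyond the scatter.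

The next compound, compound 4, `N#Cc1c(-c2ccc(N3CCCCC3)cc2)ccn2c(CC(F)(F)F)cnc12`, has not yet been measured in this assay. It differs from compound 1 in one place: piperidin-1-yl in place of phenoxy on an aromatic carbon.

Among the measured compounds shown here, no pair of measured compounds differs in just one place, so there is no measured step to lean on. Compounds 2 and 3 carry ring nitrogens and give higher numbers than compound 1, but they differ from it in several places at once, so they cannot show what this single change does. The step from compound 1 to compound 4 is therefore expected to be modest, a number 12 percentage points higher from compound 1 to compound 4 (beyond the scatter), leaning slightly upward but possibly staying within the scatter.

Compound 4 is estimated to give about 212% in this assay, with a likely range from 170% to 260%.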

Compound 4, largest response reached (Emax), in percent of the reference or control that the assay uses: 123%
Compound 4: middle estimate off by 89 percentage points, on the high side; measured number below the stated range.
By their numbers in this assay, from the lowest: compound 4; then compound 1; then compound 3; then compound 2.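

In this assay, among the compounds shown here, this is the first step that can be read at this position: piperidin-1-yl in place of phenoxy gives a number 77 percentage points lower from compound 1 to compound 4 (beyond the scatter), a large step. The place on the aromatic ring, para to a large group, is therefore sensitive to what sits there, even though both groups are uncharged six-membered rings with the same hydrogen-bond donor and acceptor counts. The data shown give no measured property that would explain the drop.

From the compounds shown here alone, with only this one replacement, it remains open whether the step follows from losing the aromatic ring, losing the oxygen, or the change of the linking atom to nitrogen. Cyclohexyl, phenylamino or morpholin-4-yl in the same place could help tell these apart.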